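This account rests on a few compounds, and the source may have more. Where it says the series, first, only, none or still open, it means among the compounds named here.

Working notes on the series. Compound 1 `CC1CCN(c2c(S(=O)(=O)c3ccc(F)cc3)cnc3ccc(F)cc23)CC1` has been measured in an assay on isolated protein for displacement of a labelled ligand from metabotropic glutamate receptor 5 (Homo sapiens), with a stated time of 60 min, tested at 1 uM (on this read-out lower numbers stand for less inhibition and higher numbers for more inhibition at the one concentration tested (going by the name of the read-out)), where compound 1 gives 87%. Compound 2 `CC1CCN(c2c(S(=O)(=O)c3ccc(F)cc3)cnc3ccc(Cl)cc23)CC1` carries chloro in place of fluoro on an aromatic carbon, and compound 2 gives 89%; the step of a number 2 percentage points higher from compound 1 to compound 2 (within the scatter) lies within the scatter, so the two read as equivalent. Compound 1 therefore stands at the lower of the two numbers, with compound 2 within the scatter of it. Compound 3 `COc1cccc(S(=O)(=O)c2cnc3ccc(F)cc3c2N2CCC(C)CC2)c1` differs from compound 1 on the sulfonyl sulfur: 3-methoxyphenyl in place of 4-fluorophenyl on a sulfonyl sulfur. Going by the values given here, no measured step bears on the group attached to the sulfonyl sulfur; the one step known concerns the aromatic carbon of the core and is within the scatter, so it offers no direction for this change. For compound 3 in this assay the expected step is a number 7 percentage points lower from compound 1 to compound 3 (within the scatter), none beyond the scatter, with wide uncertainty. Compound 3 is estimated at 80%, within 55% to 95%.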

Compound 3, a percentage reported as inhibition, at one concentration (the size of the read-out at that concentration, not a potency): 90%
The estimate for compound 3 lay 10 percentage points below the measured number; the range from low to high includes it.
By their numbers in this assay, from the lowest: compounds 1, 2 and 3 (each within the scatter of the next).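

On the sulfonyl sulfur, 3-methoxyphenyl in place of 4-fluorophenyl gives, in this assay, a number 3 percentage points higher from compound 1 to compound 3 (within the scatter), so the two compounds read as equivalent. This is the first step shown at this position, and it indicates that this one exchange of the aryl group on the sulfonyl sulfur, with fluorine leaving and methoxy entering, leaves the read-out within the scatter. No measurement at hand accounts for this result.

Going by these compounds, whether the position also accepts a very different group, such as a carboxylic acid or an amine on the phenyl ring, or a plain methyl in place of the aryl group, remains open. With a read-out taken at a single concentration, any differences in potency among these equivalent compounds also remain unresolved.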